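The source may hold more compounds than are shown below. What is called first, only, known or untested is meant among the compounds shown, and "the series" means these compounds.

Two close relatives have been tested in an ADME assay on MDBK cells (Bos taurus) for cytotoxicity, read by MTT assay, with a stated time of 96 h; on this read-out lower numbers stand for higher toxicity in this test and higher numbers for lower toxicity in this test. Compound 1 `COc1ccc(-c2nc3cc(C(C)=O)ccc3n2C2CCCCC2)c(OC)c1` gives 21000 nM. Compound 2 `C/C(=N\NC(N)=O)c1ccc2c(c1)nc(-c1ccc(Cl)cc1)n2C1CCCCC1` gives > 100000 nM, which is a limit of the assay and not a number. Compound 2 therefore stands at the limit of > 100000 nM in this assay, at which 1 of the 2 values shown sits.

Compound 3 `COc1ccc(-c2nc3cc(/C(C)=N/NC(N)=O)ccc3n2C2CCCCC2)c(OC)c1` has not yet been measured. It differs from compound 2 in one place: 2,4-dimethoxyphenyl in place of 4-chlorophenyl on an aromatic carbon. In plain terms, 2,4-dimethoxyphenyl stands in place of 4-chlorophenyl on an aromatic carbon. Going by the values given here, no measured step shows what this change does. Compound 1 also carries the 2,4-dimethoxyphenyl group and gives 21000 nM, so a move towards lower numbers is expected. The expected change is an at least 1.6-fold lower number from compound 2 to compound 3 (0.22 log units; that floor lies within the scatter), and it remains an estimate measured against a limit. Compound 3 is estimated at 60000 nM, with an expected range from 25000 nM to 100000 nM.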

Compound 3, half-maximal cytotoxic concentration: 36000 nM
Compound 3: middle estimate off by 1.7-fold (0.22 log units), on the high side; measured number inside the range.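

In this assay, exchanging 4-chlorophenyl for 2,4-dimethoxyphenyl on this aromatic carbon now has a readable size: an at least 2.7-fold lower number from compound 2 to compound 3 (0.44 log units; beyond the scatter). That size stays a bound and not an exact figure, since the value of compound 2 is a limit of the assay and not a number: the limit of > 100000 nM in this assay, at which 1 of the 3 values shown sits. Exchanging the group of 3 heavy atoms for the group of 7 heavy atoms on the other aromatic carbon, with 2,4-dimethoxyphenyl kept in place, gives a 1.7-fold higher number from compound 1 to compound 3 (0.23 log units; within the scatter), so that exchange shows no readable effect in this setting.

On these data alone, it remains open whether a single methoxy group, an amine or a carboxylic acid on that phenyl ring would move the number in the same way. As far as these compounds go, the role of the cyclohexyl group, which all three compounds share, also remains open.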